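The source may report more compounds than this note shows. Statements on the series, on what has been measured and on what is new or still open speak of the compounds shown alone.

Three compounds share one core and differ only in the aryl group that sits on an aromatic nitrogen. Compound 1 `N#CC1=C(N)Oc2c(N)cc3nc4ccccc4nc3c2C12C(=O)N(Cc1cnnn1-c1ccccc1Br)c1ccccc12` carries a 2-bromophenyl there; in an ADME assay on L02 cells (Homo sapiens) for antiproliferative activity, read by MTT assay, with a stated time of 48 h (a lower number here means a stronger inhibitor, a higher number a weaker inhibitor), compound 1 gives 29200 nM. Compound 2 `CCc1cccc(CC)c1-n1nncc1CN1C(=O)C2(C(C#N)=C(N)Oc3c(N)cc4nc5ccccc5nc4c32)c2ccccc21` carries a 2,6-diethylphenyl. In this assay compound 2 reaches only a limit, > 50000 nM. Compound 3 `N#CC1=C(N)Oc2c(N)cc3nc4ccccc4nc3c2C12C(=O)N(Cc1cnnn1-c1cc(Cl)ccc1Cl)c1ccccc12` carries a 2,5-dichlorophenyl. In this assay compound 3 likewise gives only a limit, > 50000 nM. So compound 3 stands at the weak end of what was measured, without a number of its own, a position shared with one other compound, as the limit of > 50000 nM in this assay, at which 2 of the 3 values shown sit, records. Compound 4 `N#CC1=C(N)Oc2c(N)cc3nc4ccccc4nc3c2C12C(=O)N(Cc1cnnn1-c1ccc(F)c(Cl)c1)c1ccccc12` is not yet measured; its change from compound 3 is 3-chloro-4-fluorophenyl in place of 2,5-dichlorophenyl on an aromatic nitrogen. Going by the values given here, two measured steps bear on such an exchange of the aryl group: an at least 1.7-fold higher number from compound 1 to compound 2 (0.23 log units; that floor lies within the scatter) and an at least 1.7-fold higher number from compound 1 to compound 3 (0.23 log units; that floor lies within the scatter), each starting from a number and ending at a limit. The step that the two limits leave unreadable from compound 2 to compound 3 runs between two limits and gives no size. Since every exchange of the aryl group so far ended at the limit, the expected step is an at least 1.2-fold lower number from compound 3 to compound 4 (0.09 log units; that floor lies within the scatter), with no gain beyond the scatter foreseen. The estimate for compound 4 in this assay is 40000 nM, between 15000 nM and 100000 nM.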

Compound 4, half-maximal inhibitory concentration: > 50000 nM
Compound 4 ended at the assay's limit; the forecaster's own chance of this, stated with the estimate: 55%; at least 1.2-fold (0.09 log units) between middle value and limit.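

The 3-chloro-4-fluorophenyl group now joins 2,6-diethylphenyl and 2,5-dichlorophenyl on the aromatic nitrogen, and in this assay it also gives a limit and not a number, so compound 1, with its 2-bromophenyl, remains the only one of the four with a measured number. Going by these compounds alone, the one readable new step is an at least 1.7-fold higher number from compound 1 to compound 4 (0.23 log units; that floor lies within the scatter), so even this exchange does not show that the 2-bromophenyl compound truly differs from the new one. The steps among compound 2, compound 3 and compound 4 run between limits and cannot be read, so nothing places these three in any order, and all that can be said of them together is where they sit: the limit of > 50000 nM in this assay, at which 3 of the 4 values shown sit.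

How far past the limit each of these compounds lies remains open, as does whether the number for compound 1 depends on bromine or on the place of that atom on the phenyl ring. Also open, on these data alone, is whether a different kind of group on this nitrogen, such as a benzyl group, a pyridyl ring, or a phenyl ring bearing an amine or a carboxylic acid, would bring the number down within this assay.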